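Side chain swap at the amino acid position, tail flick

The source may report more compounds than this note shows. Statements on the series, on what has been measured and on what is new or still open speak of the compounds shown alone.

Measured so far:
Compound 1 `O=C(CN(c1ncnc2c1ncn2C1CCCCO1)C1CC1)NCC(=O)OCc1ccccc1`: 55.7%
Compound 2 `C[C@@H](O)[C@H](NC(=O)CN(c1ncnc2c1ncn2C1CCCCO1)C1CC1)C(=O)OCc1ccccc1`: 23.6%
Compound 3 `NC(=O)C[C@H](NC(=O)CN(c1ncnc2c1ncn2C1CCCCO1)C1CC1)C(=O)OCc1ccccc1`: 34.5%

In a functional assay on the whole organism (Tail, strain ICR) with Mus musculus as the target, in the tail flick test, with a stated time of 30 min, at a dose of 25 umol/kg by the oral route (a higher number here means a stronger effect of the compound at the dose given, a lower number a weaker effect), compound 3 stands second of the three, above compound 2 and below compound 1. Compound 4 `N=C(N)NCCC[C@H](NC(=O)CN(c1ncnc2c1ncn2C1CCCCO1)C1CC1)C(=O)OCc1ccccc1` is not yet measured; it differs from compound 3 in one place: a group of 6 heavy atoms (3 carbon, 3 nitrogen; no ring) in place of a group of 3 heavy atoms (1 carbon, 1 nitrogen, 1 oxygen; no ring), on a saturated chain carbon, two bonds along the chain from an amide-type nitrogen and a carbonyl carbon. The measured steps that bear on this all change the group at the same chain position: a number 32.1 percentage points lower from compound 1 to compound 2 (beyond the scatter), a number 21.2 percentage points lower from compound 1 to compound 3 (beyond the scatter) and a number 10.9 percentage points higher from compound 2 to compound 3 (beyond the scatter). Both added side chains lowered the read-out relative to the bare chain, and the two side chains differed only modestly from each other. A further exchange of one side chain for another is therefore expected to give a modest step, most likely downward, a number 6.5 percentage points lower from compound 3 to compound 4 (within the scatter). Compound 4 is estimated at 28%, within 12% to 48%.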

Compound 4, a percentage reported as activity, at one dose (the size of the read-out at that dose, not a potency): 34.3%
Estimate against measurement, compound 4: 6.3 percentage points below, and the stated range covers the measured number.
By their numbers in this assay, from the lowest: compound 2; then compounds 4 and 3 (each within the scatter of the next); then compound 1.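

In this assay, the group of 6 heavy atoms in place of carbamoyl gives a number 0.2 percentage points lower from compound 3 to compound 4 (within the scatter), so the two side chains cannot be told apart here despite the larger group and its added hydrogen-bond donors. The other two steps, a number 10.7 percentage points higher from compound 2 to compound 4 (beyond the scatter) and a number 21.4 percentage points lower from compound 1 to compound 4 (beyond the scatter), show that compound 4 also stays clear of the 1-hydroxyethyl side chain and that all three side chains sit below the bare chain of compound 1. Nothing available explains these differences. Still open, on these data alone, is whether a small methyl, a carboxylic acid or a plain amine at this position would come closer to compound 1.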